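Trading 4-methylphenyl for 3-methoxyphenyl on the shared core

This account rests on a few compounds, and the source may have more. Where it says the series, first, only, none or still open, it means among the compounds named here.

Measured so far in a functional assay on HeLa cells (Homo sapiens) for antiproliferative activity, read by MTT assay, with a stated time of 72 h; a higher number here means a weaker inhibitor, a lower number a stronger inhibitor
- Compound 1 `COc1ncc(-c2ccc3c(c2)N(c2ccc(C)cc2)C(=O)CO3)cc1NS(=O)(=O)c1ccc(F)cc1` gives 4650 nM
- Compound 2 `O=C1COc2ccc(-c3cccc(NS(=O)(=O)c4ccc(F)cc4)c3)cc2N1` gives > 40000 nM (a limit of the assay)
- Compound 3 `COc1ccc(N2C(=O)COc3ccc(-c4ccc(O)cc4)cc32)cc1` gives 16400 nM

Compound 1 (4650 nM) has the lowest number of the two true measurements, which makes it the stronger of that pair. Compound 3 (16400 nM) lies higher, beyond the usual scatter. The entry for compound 2 (> 40000 nM) is a limit and not a number.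

Compound 4 `COc1cccc(N2C(=O)COc3ccc(-c4cnc(OC)c(NS(=O)(=O)c5ccc(F)cc5)c4)cc32)c1` keeps the core of compound 1 but has 3-methoxyphenyl in place of 4-methylphenyl on an amide-type nitrogen in a ring. Going by the values given here, no measured pair shows this change alone, so the step expected in this assay is none beyond the scatter (a 1.2-fold lower number from compound 1 to compound 4 (0.07 log units; within the scatter)). For compound 4 the estimated value is 4000 nM within an expected range from 1500 nM to 12000 nM in this estimate.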

Compound 4, half-maximal inhibitory concentration: > 40000 nM
Compound 4: only a limit was reported (the forecaster's own chance of this, stated with the estimate: 5%); at least 10-fold (1.00 log units) between middle value and limit.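

In this assay the group on this amide-type nitrogen proves to matter: 3-methoxyphenyl in place of 4-methylphenyl gives an at least 8.6-fold higher number from compound 1 to compound 4 (0.93 log units; beyond the scatter) on the shared core. Going by these compounds alone, no earlier pair isolated a change at this place. The entry for compound 4 is a limit and not a number, so the true size of this step stays unknown: the limit of > 40000 nM in this assay, at which 2 of the 4 values shown sit.

Still open, as far as these compounds go, is whether any other group on this nitrogen can match or better compound 1, and how a phenyl ring carrying an amine or a carboxylic acid would behave here.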